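This account rests on a few compounds, and the source may have more. Where it says the series, first, only, none or still open, it means among the compounds named here.

Measured so far in a functional assay on HCT-116 cells (Homo sapiens) for antiproliferative activity, with a stated time of 48 h; on this read-out lower numbers stand for higher toxicity in this test and higher numbers for lower toxicity in this test: compound 1 `Cc1cc(O)c(C2=NN(c3ccc(S(N)(=O)=O)cc3)C(c3ccccc3O)C2)cc1Cl` gives 5500 nM; compound 2 `Cc1cc(O)c(C2=NN(c3ccc(S(N)(=O)=O)cc3)C(c3ccccc3Cl)C2)cc1Cl` gives 5610 nM; compound 3 `Cc1cc(O)c(C2=NN(c3ccc(S(N)(=O)=O)cc3)C(/C=C/c3ccccc3)C2)cc1Cl` gives 38200 nM.

Compound 3 stands highest of the three numbers in this assay. The step from compound 2 to compound 3 was a 6.8-fold higher number from compound 2 to compound 3 (0.83 log units; beyond the scatter), and the step from compound 1 to compound 3 was a 6.9-fold higher number from compound 1 to compound 3 (0.84 log units; beyond the scatter), so compound 3 lies clearly apart from both of the others.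

Compound 4 `COc1ccc(C2CC(c3cc(Cl)c(C)cc3O)=NN2c2ccc(S(N)(=O)=O)cc2)cc1OC` is the next compound to be measured. It differs from compound 3 by 3,4-dimethoxyphenyl in place of 2-phenylethenyl on a saturated ring carbon. The two steps that bear on this change are the ones just named, in which a directly attached aryl group gave way to the 2-phenylethenyl group and the number rose by a modest, consistent amount each time. Compound 4 goes the other way, putting an aryl group back on that saturated ring carbon. Within the data shown here, the step of a 1.0-fold higher number from compound 1 to compound 2 (0.01 log units; within the scatter) shows that exchanging one substituent on such an aryl ring for another left the number within the scatter, though no measured compound carries a 3,4-dimethoxyphenyl group, so its own pattern is untested.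

A modest step downward in this assay is therefore expected for compound 4, of about a 5.5-fold lower number from compound 3 to compound 4 (0.74 log units; beyond the scatter). The estimate for compound 4 is 7000 nM, with a range from 2500 nM to 20000 nM.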

Compound 4, concentration lethal to 50% of the cells: 12400 nM
Compound 4: the middle estimate sits 1.8-fold (0.25 log units) below what was measured, and the stated range covers the measured number.
By their numbers in this assay, from the lowest: compounds 1 and 2 (each within the scatter of the next); then compound 4; then compound 3.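

On the saturated ring carbon next to the ring nitrogen, in this assay, 3,4-dimethoxyphenyl in place of 2-phenylethenyl gave a 3.1-fold lower number from compound 3 to compound 4 (0.49 log units; beyond the scatter), so all three compounds with a directly attached aryl group now have lower numbers than the 2-phenylethenyl compound. The aryl groups are no longer equivalent, however: 3,4-dimethoxyphenyl in place of 2-chlorophenyl gave a 2.2-fold higher number from compound 2 to compound 4 (0.34 log units; beyond the scatter), and in place of 2-hydroxyphenyl it gave a 2.3-fold higher number from compound 1 to compound 4 (0.35 log units; beyond the scatter), which places compound 4 between compound 3 and the matched pair of compound 1 and compound 2, and shows that the substitution on this aryl ring can shift the number beyond the scatter. No independent measurement bears on why these groups differ.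

The 3,4-dimethoxyphenyl group differs from 2-chlorophenyl and 2-hydroxyphenyl in both the kind and the arrangement of its substituents, so a 4-methoxyphenyl group at this carbon would be needed to begin separating the two. From the compounds shown here alone, it also remains open whether a 2-phenylethyl group, which lacks the double bond of 2-phenylethenyl, would stay as high as compound 3 or fall towards the aryl compounds.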